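Lengthening the Ether Group on a Bile Acid Receptor Agonist

A few compounds are considered here, and "the series" means these few. Any claim that something is new, unique, unknown or untested is made for them only; others in the source may bear on it.

Measured compounds:
compound 1, `CO[C@]1(c2ccc(OCc3c(-c4c(Cl)cccc4Cl)noc3C3CC3)cc2Cl)C[C@H](c2cccc(C(=O)O)c2)C1`: 102 nM
compound 2, `O=C(O)c1cccc(N2CC(O)(c3ccc(OCc4c(-c5c(Cl)cccc5Cl)noc4C4CC4)cc3Cl)C2)c1`: 86 nM

Both numbers come from an assay on HEK293 cells for agonist activity at Bile acid receptor (Homo sapiens); a lower number here means that less compound is needed, a higher number that more compound is needed for the effect. Compound 1 holds the higher of the two numbers, but its gap to compound 2 lies within the scatter, so the two compounds cannot be ranked against each other.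

Compound 3 `O=C(O)c1cccc([C@H]2C[C@](OCCO)(c3ccc(OCc4c(-c5c(Cl)cccc5Cl)noc4C4CC4)cc3Cl)C2)c1` has not yet been measured. It differs from compound 1 in one place: hydroxymethyl in place of hydrogen on a saturated chain carbon bound to an oxygen on a saturated carbon. Among the compounds with values here, no pair of measured compounds shows what such a change does, so the expectation rests on compound 1 alone. A change of this kind, a hydrogen giving way to a hydroxymethyl at a chain carbon, is expected to shift the number little, with a step of a 1.2-fold lower number from compound 1 to compound 3 (0.08 log units; within the scatter) that stays within the scatter. Compound 3 is therefore estimated at 85 nM, with a likely range from 30 nM to 250 nM.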

Compound 3, half-maximal effective concentration: 377 nM
Compound 3: the middle estimate sits 4.4-fold (0.65 log units) below what was measured, and the stated range ends below it.
By their numbers in this assay, from the lowest: compounds 2 and 1 (each within the scatter of the next); then compound 3.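

Going from methoxy to 2-hydroxyethoxy on the core of compound 1 is not a neutral change in this assay and gives a 3.7-fold higher number from compound 1 to compound 3 (0.57 log units; beyond the scatter) at this position, so more compound is needed for the same effect. Within the data shown here, this is the first sign that the group on this ether oxygen affects the number, and that a hydroxymethyl on the saturated chain carbon bound to that oxygen is not tolerated without cost. Nothing available here explains the rise.

A single step cannot show whether the extra chain length or its hydroxyl goes with the higher number. A plain ethoxy group would separate those two, and a 2-aminoethoxy group would show whether a different group at the chain end behaves the same way.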